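The compounds below may be only part of what the source reports. "The series", "measured", "known", "first", "only" and "open" are said of these compounds alone.

Working notes on the series, read in an ADME assay on A549 cells (Homo sapiens) for cytotoxicity, read by CellTiter-Glo; a lower number here means that less compound is tolerated, a higher number that more compound is tolerated. Compound 1 `Cc1c(Cc2ccccc2)c(=O)oc2cc(OCC(O)CNc3ccccc3)ccc12` has no number to start from: compound 1 gives > 100000 nM, which is a limit of the assay. Compound 3 `Cc1ccc2nc(NCC(O)COc3ccc4c(C)c(Cc5ccccc5)c(=O)oc4c3)sc2c1` also gives only a limit, with compound 3 at > 100000 nM. The starting point therefore sits at the limit of > 100000 nM in this assay, at which 2 of the 3 values shown sit. Among the measured compounds shown here, compound 2 `Cc1c(Cc2ccccc2)c(=O)oc2cc(OCC(O)CNCCCCCCO)ccc12` is the one measured number, with compound 2 at 40300 nM.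

Compound 4 `Cc1c(Cc2ccccc2)c(=O)oc2cc(OCCCNc3nccs3)ccc12` has 2-((1,3-thiazol-2-yl)amino)ethyl in place of 2-anilino-1-hydroxyethyl on a saturated chain carbon bound to an oxygen on an aromatic ring.

The nearest evidence comes from changes on the amine nitrogen. 6-Hydroxyhexyl in place of phenyl gave an at least 2.4-fold lower number from compound 1 to compound 2 (0.39 log units; beyond the scatter). 6-Methyl-1,3-benzothiazol-2-yl in place of 6-hydroxyhexyl gave an at least 2.4-fold higher number from compound 2 to compound 3 (0.39 log units; beyond the scatter), while the same group in place of phenyl gave a step that the two limits leave unreadable from compound 1 to compound 3. Both aromatic groups therefore stay at the limit, and compound 2 goes against them. For the measured compounds named here, compound 4 keeps an aromatic ring on the amine nitrogen, but no measured step tests the loss of the hydroxyl-bearing carbon.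

At most a modest fall is expected, estimated as an at least 1.4-fold lower number from compound 1 to compound 4 (0.15 log units; that floor lies within the scatter). The estimated value for compound 4 is 70000 nM, with an expected range of 25000 nM to 100000 nM.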

Compound 4, half-maximal cytotoxic concentration: 50100 nM
The estimate for compound 4 lay 1.4-fold (0.15 log units) above the measured number; the measured number falls inside the stated range.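

In this assay the replacement of 2-anilino-1-hydroxyethyl by 2-((1,3-thiazol-2-yl)amino)ethyl gives an at least 1.9-fold lower number from compound 1 to compound 4 (0.30 log units; that floor lies within the scatter). Compound 4 is the first compound shown with an aromatic ring on the amine nitrogen to give a measured number rather than a limit, so such a ring does not by itself hold a compound at the limit, and compound 4 goes against the reading drawn from compound 1 and compound 3. The size of this step stays a floor because compound 1 gives only a limit: the limit of > 100000 nM in this assay, at which 2 of the 4 values shown sit.

The change swaps the phenyl for a five-membered aromatic ring with 2 hetero atoms and also removes the hydroxyl-bearing carbon, so the step cannot assign the measured number to either part. A 2-anilinoethyl group on the same saturated chain carbon, or a 2-((1,3-thiazol-2-yl)amino)-1-hydroxyethyl group there, would separate the two parts, and the compounds shown leave open whether either would stay at the limit.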